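Enlarging the Alkyl Group: Expected Gain in Potency

The source may hold more compounds than are shown below. What is called first, only, known or untested is meant among the compounds shown, and "the series" means these compounds.

Compound 3 `CCc1ncc(-c2nc(C(F)(F)F)sc2N2CCN(C(=O)Cn3nc(C)nc3C)[C@H](C)C2)cn1` gives 14 nM in a functional assay on CHO-K1 cells for antagonist activity at C-X-C chemokine receptor type 3 (Homo sapiens), read by FLIPR, with a stated time of 10 min; a lower number here means a stronger inhibitor, a higher number a weaker inhibitor. Compound 1 `COc1ncc(-c2nc(C(F)(F)F)sc2N2CCN(C(=O)Cn3nc(C)nc3C)[C@H](C)C2)cn1` gives 25 nM, a result within the scatter of compound 3, while compound 2 `Cc1nc(C)n(CC(=O)N2CCN(c3sc(C(F)(F)F)nc3-c3cnc(OC(C)C)nc3)C[C@H]2C)n1` gives 3.4 nM, the lowest number of the three. Compound 4 `Cc1nc(C)n(CC(=O)N2CCN(c3sc(C(F)(F)F)nc3-c3cnc(C(C)(C)C)nc3)C[C@H]2C)n1` differs from compound 3 by tert-butyl in place of ethyl on an aromatic carbon. The most telling earlier step is a 7.4-fold lower number from compound 1 to compound 2 (0.87 log units; beyond the scatter), where the group on that aromatic carbon was likewise enlarged; the related step of a 4.1-fold higher number from compound 2 to compound 3 (0.61 log units; beyond the scatter) points the same way, with the bulkier group giving the lower number. A step of similar size toward a lower number is therefore expected here. Compound 4 is estimated at 5 nM, within a range of 1.5 nM to 15 nM, which means an expected step of a 2.8-fold lower number from compound 3 to compound 4 (0.45 log units; beyond the scatter).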

Compound 4, half-maximal inhibitory concentration: 8.7 nM
Estimate against measurement, compound 4: 1.7-fold (0.24 log units) below, within the range that was stated.
By their numbers in this assay, from the lowest: compound 2; then compounds 4, 3 and 1 (each within the scatter of the next, the first and the last beyond it).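

In this assay, tert-butyl in place of ethyl gives a 1.6-fold lower number from compound 3 to compound 4 (0.21 log units; within the scatter), so at this position the larger carbon group does not separate from ethyl. Tert-butyl in place of methoxy gives a 2.9-fold lower number from compound 1 to compound 4 (0.46 log units; beyond the scatter), yet tert-butyl in place of isopropoxy gives a 2.6-fold higher number from compound 2 to compound 4 (0.41 log units; beyond the scatter), so enlarging the carbon group does not reach the number seen with isopropoxy. Nothing shown here gives a reason for these differences.

Open, going by these compounds, is whether the oxygen of isopropoxy matters, which a directly attached isopropyl group could test. Also open, on these data alone, is how a cyclopropyl group or an amine would compare at this position.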